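This account rests on a few compounds, and the source may have more. Where it says the series, first, only, none or still open, it means among the compounds named here.

In an in vitro assay on HEK385-7 cells for displacement of a labelled ligand from prostaglandin D2 receptor 2 (Homo sapiens) (on this read-out higher numbers stand for weaker inhibition and lower numbers for stronger inhibition), compound 3 `O=C(O)Cc1sc(C(Cc2ccccc2)c2ccccc2)nc1-c1ccc(Cl)cc1` gives 56 nM, the lowest of the three numbers. Within the data shown here, compound 2 `O=C(O)Cc1sc(CSc2ccccc2)nc1-c1ccc(Cl)cc1` gives 250 nM and compound 1 `O=C(O)Cc1sc(NCc2ccccc2)nc1-c1ccc(Cl)cc1` gives 440 nM; the single measured step between them, a 1.8-fold lower number from compound 1 to compound 2 (0.25 log units; within the scatter), concerns a replacement on an aromatic carbon and stays within the scatter. Compound 4 `O=C(O)Cc1sc(C(c2ccccc2)c2ccccn2)nc1-c1ccc(Cl)cc1` differs from compound 3 by pyridin-2-yl in place of benzyl on a saturated chain carbon bound to two aromatic carbons. Among the measured compounds shown here, no measured step touches this saturated chain carbon, so the expectation rests on the structural change alone, without a comparison to lean on. With nothing measured to anchor it, only a modest step, if any, is expected in this assay, a 2.0-fold higher number from compound 3 to compound 4 (0.29 log units; within the scatter). Compound 4 is therefore estimated at 110 nM, with a range from 35 nM to 350 nM.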

Compound 4, half-maximal inhibitory concentration: 810 nM
For compound 4 the middle estimate is 7.4-fold (0.87 log units) below the measured one; measured number above the stated range.
By their numbers in this assay, from the lowest: compound 3; then compounds 2, 1 and 4 (each within the scatter of the next, the first and the last beyond it).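

Among these compounds, at the saturated chain carbon bound to two aromatic carbons, this assay responds strongly to the change of group: pyridin-2-yl in place of benzyl gives a 14-fold higher number from compound 3 to compound 4 (1.16 log units; beyond the scatter), the first measured step at this carbon. Benzyl and pyridin-2-yl are therefore not interchangeable here. Nothing measured accounts for the size of this step. The compounds shown leave open whether the step follows the ring nitrogen or the missing methylene of benzyl. Phenyl or pyridin-2-ylmethyl on this carbon would separate the two, but neither stands among them.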